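Methoxy for nitro on the aryl ring of compound 2

The source may report more compounds than this note shows. Statements on the series, on what has been measured and on what is new or still open speak of the compounds shown alone.

Measured compounds in a functional assay (Cavia porcellus) for antagonist activity at Serotonin 3 (5-HT3) receptor (Homo sapiens); on this read-out lower numbers stand for stronger inhibition and higher numbers for weaker inhibition:
- compound 1 `Cc1[nH]cnc1CN1CCN(c2cccc(Br)c2)C1=O` gives 10.4 nM
- compound 2 `Cc1[nH]cnc1CN1CCN(c2cccc([N+](=O)[O-])c2)C1=O` gives 125 nM

Compound 2 stands as the highest of the two numbers in this assay; its nearest neighbour is compound 1, the step between them lying beyond the scatter.

Compound 3 `COc1cccc(N2CCN(Cc3nc[nH]c3C)C2=O)c1` differs from compound 2 by methoxy in place of nitro on an aromatic carbon. Among the measured compounds shown here, only one measured step bears on this change: a 12-fold higher number from compound 1 to compound 2 (1.08 log units; beyond the scatter). Nitro thus brought a large weakening relative to bromo on this carbon; methoxy is a new group, untested in the series, so its effect can only be bracketed between those two measured values. A partial reversal of that step is expected, giving a 3.6-fold lower number from compound 2 to compound 3 (0.55 log units; beyond the scatter), but a result within the scatter of compound 2 is not excluded. Compound 3 is estimated at 35 nM in this assay, with a range from 9 nM to 140 nM.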

Compound 3, antagonist equilibrium constant: 67.8 nM
The estimate for compound 3 lay 1.9-fold (0.29 log units) below the measured number, and the stated range covers the measured number.
By their numbers in this assay, from the lowest: compound 1; then compounds 3 and 2 (each within the scatter of the next).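

In this assay, methoxy and nitro on this aromatic carbon are not separated (a 1.8-fold lower number from compound 2 to compound 3 (0.27 log units; within the scatter)), so going from 3 heavy atoms to 2, and from 2 hydrogen-bond acceptors to 1, leaves no readable mark on the read-out. The gap to bromo persists (a 6.5-fold higher number from compound 1 to compound 3 (0.81 log units; beyond the scatter)), and compound 1 now stands apart from both other groups, with its steps to compound 2 and compound 3 each beyond the scatter. No measured data bear on why bromo differs from these two groups.

From the compounds shown here alone, whether this advantage belongs to bromo alone or extends to chloro or methyl on the same carbon remains open. An amine or a carboxylic acid there would show whether the read-out can move outside the span set by these three groups.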